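The source may hold more compounds than are shown below. What is called first, only, known or untested is meant among the compounds shown, and "the series" means these compounds.

Compound 1 `Cn1c(N2N=C(c3ccccc3)CC2c2ccccc2)nc(-c2ccccc2)c(C#N)c1=O` is the point of reference for the set. In a functional assay on HT-29 cells (Homo sapiens) for antiproliferative activity, with a stated time of 72 h (a higher number here means a weaker inhibitor, a lower number a stronger inhibitor), compound 1 gives 2490 nM. Compound 2 `COc1ccc(C2CC(c3ccccc3)=NN2c2nc(-c3ccccc3)c(C#N)c(=O)n2C)cc1` differs from compound 1 in one place: methoxy in place of hydrogen on an aromatic carbon. In this assay compound 2 gives 14700 nM, and the step of a 5.9-fold higher number from compound 1 to compound 2 (0.77 log units; beyond the scatter) is modest but beyond the scatter. Compound 3 `Cn1c(N2N=C(c3ccc(Cl)cc3)CC2c2ccccc2)nc(-c2ccc(Cl)cc2)c(C#N)c1=O` rests on a different core; the difference between the core of compound 1 and the core of compound 3 is not broken down here. In this assay compound 3 gives 8720 nM, a number that lies within the scatter of the number for compound 2 and beyond the scatter above the number for compound 1.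

Compound 4 `COc1ccc(C2CC(c3ccc(Cl)cc3)=NN2c2nc(-c3ccc(Cl)cc3)c(C#N)c(=O)n2C)cc1` has not yet been measured. It differs from compound 3 in one place: methoxy in place of hydrogen on an aromatic carbon. The place is described in the same words as for the change from compound 1 to compound 2, so this is the same change made on the other core. Within the data shown here, with only one earlier example, the expectation rests on it alone. The expected step is a 4.6-fold higher number from compound 3 to compound 4 (0.66 log units; beyond the scatter), because the same change gave a 5.9-fold higher number from compound 1 to compound 2 (0.77 log units; beyond the scatter). Compound 4 is therefore estimated at 40000 nM in this assay. The lower end of the estimate for compound 4 is 15000 nM. The upper end of the estimate for compound 4 is 120000 nM. Whether the second core carries the change over in the same way can only be told once compound 4 has been measured.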

Compound 4, half-maximal inhibitory concentration: 15100 nM
Compound 4: the middle estimate sits 2.6-fold (0.42 log units) above what was measured, and the stated range covers the measured number.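

In this assay, the change from phenyl to 4-methoxyphenyl on the second core gives a 1.7-fold higher number from compound 3 to compound 4 (0.24 log units; within the scatter), so on that core the effect of the methoxy group cannot be told apart from the usual scatter of repeated measurements. The change therefore did not carry over from one core to the other at the same size, and the gap between the two steps is itself larger than repeated measurements would explain: the same change on two cores in this assay, a 5.9-fold higher number (0.77 log units; beyond the scatter) from compound 1 to compound 2 and a 1.7-fold higher number (0.24 log units; within the scatter) from compound 3 to compound 4, 3.4-fold (0.53 log units) apart, beyond the scatter of two such steps With a single pair on each core, this shows only that the effect of this change depends on the core in these two cases; it does not show which difference between the cores is responsible, nor does it give a rule for any further core in the series.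

The compounds shown leave open how other groups at the same place on the aromatic ring, such as an amine, a hydroxyl or a carboxylic acid, would behave on these two cores. They also leave open whether a longer chain such as ethoxy in place of methoxy would give steps that differ between the cores in the same way.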